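This account rests on a few compounds, and the source may have more. Where it says the series, first, only, none or still open, it means among the compounds named here.

Working notes on the series. Compound 3 `CC#CC(CC(=O)O)c1ccc(OCc2ccn3cc(-c4cccc(C)c4)nc3c2)cc1` stands highest of the three numbers in an assay on isolated protein for agonist activity at Free fatty acid receptor 1 (Homo sapiens) (a higher number here means that more compound is needed for the effect, a lower number that less compound is needed), with 1510 nM; compound 2 `CC#CC(CC(=O)O)c1ccc(OCc2ccn3cc(-c4ccc(CC)cc4)nc3c2)cc1` gives 671 nM and compound 1 `CC#CC(CC(=O)O)c1ccc(OCc2ccc3nc(-c4ccc(CC)cc4)cn3c2)cc1` gives 496 nM. Compound 4 `CC#CC(CC(=O)O)c1ccc(OCc2ccn3cc(-c4ccccc4F)nc3c2)cc1` is set apart from compound 3 by 2-fluorophenyl in place of 3-methylphenyl on an aromatic carbon. Within the data shown here, the only measured step that bears on this position is a 2.3-fold higher number from compound 2 to compound 3 (0.35 log units; beyond the scatter), a modest shift for one substituted phenyl exchanged for another. Among the measured compounds shown here, no measured pair covers a fluorine or a 2-substituted phenyl here, so the direction is open; a step of similar modest size, in either direction, or none beyond the scatter, is expected. Compound 4 is therefore estimated at 1100 nM, range 450 nM to 2800 nM, an expected step of a 1.4-fold lower number from compound 3 to compound 4 (0.14 log units; within the scatter).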

Compound 4, half-maximal effective concentration: 705 nM
Estimate against measurement, compound 4: 1.6-fold (0.19 log units) above; the range from low to high includes it.
By their numbers in this assay, from the lowest: compounds 1, 2 and 4 (each within the scatter of the next); then compound 3.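

Exchanging 3-methylphenyl for 2-fluorophenyl gives a 2.1-fold lower number from compound 3 to compound 4 (0.33 log units; beyond the scatter), the only step down shown at this position. Exchanging 4-ethylphenyl for 2-fluorophenyl gives a 1.1-fold higher number from compound 2 to compound 4 (0.02 log units; within the scatter), so these two groups cannot be told apart here, and among the three substituted phenyls only the 3-methylphenyl of compound 3 stands apart. No measurement at hand accounts for this difference.

Unsubstituted phenyl, 2-methylphenyl and 3-fluorophenyl remain open, and they would separate the kind of substituent from its place on the phenyl. Also open, on these data alone, is whether 2-fluorophenyl gives a similar number on the core of compound 1.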